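Aminoalkyl group exchange from compound 2 to compound 3

The source may report more compounds than this note shows. Statements on the series, on what has been measured and on what is new or still open speak of the compounds shown alone.

Measured so far in a functional assay on the whole organism (strain Swiss Albino) with Mus musculus as the target; a lower number here means that less compound is needed, a higher number that more compound is needed for the effect
- compound 1 `Cc1cc(Cl)cc(C)c1NC(=O)[C@@H](C)N`: 17.8 mg/kg
- compound 2 `Cc1cc(Cl)ccc1NC(=O)[C@@H](C)N`: 39.2 mg/kg

Compound 2 holds the higher of the two numbers. Going by the values given here, the only measured step is a 2.2-fold higher number from compound 1 to compound 2 (0.34 log units; beyond the scatter), a modest one, with hydrogen in place of methyl on an aromatic carbon.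

Compound 3 `Cc1cc(Cl)ccc1NC(=O)[C@@H](N)C(C)C` differs from compound 2 in one place, with 1-amino-2-methylpropyl in place of 1-aminoethyl on a carbonyl carbon. Among the compounds with values here, no measured step involves this group, so the aromatic step serves only as a rough guide to the size of a single change. It gives no direction for this one. A step no larger than that one is expected in this assay, perhaps within the scatter, with a weak lean towards a higher number. The expected step is a 1.4-fold higher number from compound 2 to compound 3 (0.15 log units; within the scatter) and its direction remains uncertain. For compound 3 the estimate is 55 mg/kg, with an expected range from 22 mg/kg to 140 mg/kg.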

Compound 3, dose for half-maximal effect: 25.9 mg/kg
Compound 3: middle estimate off by 2.1-fold (0.33 log units), on the high side; low and high end bracket the measured number.
By their numbers in this assay, from the lowest: compounds 1, 3 and 2 (each within the scatter of the next, the first and the last beyond it).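

In this assay, going by these compounds alone, 1-amino-2-methylpropyl in place of 1-aminoethyl on the carbonyl carbon gives a 1.5-fold lower number from compound 2 to compound 3 (0.18 log units; within the scatter), so this position accepts a group of 5 heavy atoms in place of one of 3 with no step that stands clear of the scatter. Within the data shown here, this is the first reading at this position, and it contrasts with the only earlier step, on an aromatic carbon, which was a 2.2-fold higher number from compound 1 to compound 2 (0.34 log units; beyond the scatter) and stands beyond the scatter. No measurement here accounts for the outcome of the exchange at the carbonyl carbon.

Going by these compounds, it remains open whether the tolerance seen with 1-amino-2-methylpropyl extends to a longer chain, a benzyl group or a carboxylic acid on the same carbon, or to the opposite configuration at the defined stereocentre. Also open, on these data alone, is whether the step seen for the aromatic methyl carries over when 1-amino-2-methylpropyl replaces 1-aminoethyl, since that methyl has so far been read only with 1-aminoethyl in place.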